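From Methyl to Cyclohexyl on an Aromatic Nitrogen

This account rests on a few compounds, and the source may have more. Where it says the series, first, only, none or still open, it means among the compounds named here.

In an ADME assay on BHK cells (Mesocricetus auratus) for cytotoxicity, read by MTT assay, with a stated time of 96 h (on this read-out higher numbers stand for lower toxicity in this test and lower numbers for higher toxicity in this test), compound 1 (`O=[N+]([O-])c1ccc(-c2nc3cc(C(F)(F)F)ccc3[nH]2)cc1`) gives 18000 nM and compound 2 (`COc1ccc(-c2nc3cc(Cl)c(Cl)cc3[nH]2)c([N+](=O)[O-])c1`) gives 80000 nM as measured numbers. Compound 3 (`Cn1c(-c2ccc([N+](=O)[O-])cc2)nc2cc(C(F)(F)F)ccc21`) gives > 100000 nM in this assay and this is a limit of the assay, not a number. It therefore stands at the top of the measured range, with no exact value to start from.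

Compound 4 (`O=[N+]([O-])c1ccc(-c2nc3cc(C(F)(F)F)ccc3n2C2CCCCC2)cc1`) carries cyclohexyl in place of methyl on an aromatic nitrogen and is otherwise unchanged from compound 3. Going by the values given here, one measured step bears on this change. Among the compounds with values here, with methyl in place of hydrogen on an aromatic nitrogen, the data show an at least 5.5-fold higher number from compound 1 to compound 3 (0.74 log units; beyond the scatter) as the only guide. That step says nothing direct about a group as large as cyclohexyl, so its size cannot simply be carried over.

A moderate fall in this assay is expected, and a result that again reaches the limit would be no surprise. The expected step is an at least 2.0-fold lower number from compound 3 to compound 4 (0.30 log units; that floor lies within the scatter) in this estimate. For compound 4 the estimated value is 50000 nM with an expected range from 15000 nM to 100000 nM in this test.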

Compound 4, half-maximal cytotoxic concentration: > 100000 nM
Compound 4: no number, only a limit (the forecaster's own chance of this, stated with the estimate: 40%); at least 2.0-fold (0.30 log units) between middle value and limit.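

Compound 4 shows that a group far larger than methyl can sit on this aromatic nitrogen without bringing the number back into the measured range of this assay. Cyclohexyl in place of hydrogen gives an at least 5.5-fold higher number from compound 1 to compound 4 (0.74 log units; beyond the scatter), a step in the same direction as the one seen with methyl, an at least 5.5-fold higher number from compound 1 to compound 3 (0.74 log units; beyond the scatter); within this pair of changes, then, both groups on the nitrogen carry the number beyond the scatter from that of compound 1. Cyclohexyl in place of methyl cannot be sized, however, because compound 3 and compound 4 both rest on a limit and not on a number: the limit of > 100000 nM in this assay, at which 2 of the 4 values shown sit.

From the compounds shown here alone, it remains open how far compound 3 and compound 4 lie past that limit, and so whether cyclohexyl differs from methyl at all in this assay. The compounds shown also leave open whether an amine, a carboxylic acid or a longer chain on this aromatic nitrogen would keep the number at the limit or bring it back towards that of compound 1.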